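Cyclohexyl to benzyl on the ring nitrogen of compound 1

The source may report more compounds than this note shows. Statements on the series, on what has been measured and on what is new or still open speak of the compounds shown alone.

Measured so far:
compound 1, `c1ccc2c(-c3cn4ccnc4c(-c4ccc5ncn(C6CCCCC6)c5c4)n3)cccc2c1`: 44.7%
compound 2, `c1cn2cc(-c3ccsc3)nc(-c3ccc4ncn(C5CCCCC5)c4c3)c2n1`: 30%
compound 3, `c1csc(-c2cn3ccnc3c(-c3ccc4ncn(C5CCCCC5)c4c3)n2)c1`: 30.8%

In a functional assay on MOLT-4 cells (Homo sapiens) for inhibition, read by sulforhodamine B assay, with a stated time of 48 h, tested at 10 uM (a lower number here means less inhibition, a higher number more inhibition at the concentration tested (going by the name of the read-out)), compound 1 holds the highest of the three numbers. Its nearest neighbour is compound 3, a number 13.9 percentage points lower from compound 1 to compound 3 (beyond the scatter); the furthest is compound 2, a number 14.7 percentage points lower from compound 1 to compound 2 (beyond the scatter). Between the two thiophenes the difference is a number 0.8 percentage points higher from compound 2 to compound 3 (within the scatter), so compound 2 and compound 3 cannot be told apart on these numbers.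

Compound 4, `c1ccc(Cn2cnc3ccc(-c4nc(-c5cccc6ccccc56)cn5ccnc45)cc32)cc1`, differs from compound 1 in one place only: benzyl in place of cyclohexyl on an aromatic nitrogen. All three measured steps change the group on an aromatic carbon of the shared core; none of them touches the aromatic nitrogen of the five-membered ring where the cyclohexyl sits. Among the measured compounds shown here, no measured step therefore bears directly on the change from compound 1 to compound 4, and the only guide is the value of compound 1 itself in this assay.

With nothing to point either way, compound 1 is taken as the anchor and no step beyond the scatter is expected. The expected step is a number 0.3 percentage points higher from compound 1 to compound 4 (within the scatter). Compound 4 is therefore estimated at 45%, within a wide band from 25% to 65%, the breadth reflecting the absence of any measured change at this position.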

Compound 4, a percentage reported as inhibition, at one concentration (the size of the read-out at that concentration, not a potency): 22.3%
Compound 4: middle estimate off by 22.7 percentage points, on the high side; the measured number lies below the stated range.
By their numbers in this assay, from the lowest: compounds 4, 2 and 3 (each within the scatter of the next); then compound 1.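

In this assay, the group on the aromatic nitrogen of the five-membered ring matters to the read-out: benzyl in place of cyclohexyl gives a clear loss of inhibition (a number 22.4 percentage points lower from compound 1 to compound 4 (beyond the scatter)). Among the compounds shown here, the earlier steps changed only the group on an aromatic carbon of the shared core, so this is the first sign that the number also responds at the ring nitrogen, with naphthalen-1-yl held constant. Nothing available explains the step, and the data do not separate the aromatic ring of benzyl from its extra carbon as the feature that matters.

Open, going by these compounds, is how the number responds to cyclohexylmethyl or phenyl on this nitrogen, groups that would separate ring type from the extra carbon, and to a smaller group such as methyl. Also open, on these data alone, is whether the loss carries over when thiophen-2-yl or thiophen-3-yl replaces naphthalen-1-yl, since the nitrogen change has been read on the naphthalen-1-yl compounds alone.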